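Swapping Methyl for Bromo Beside a Free Hydroxy Group

The source may report more compounds than this note shows. Statements on the series, on what has been measured and on what is new or still open speak of the compounds shown alone.

Of the compounds shown here, three have so far been tested in a functional assay on MCF7 cells (Homo sapiens) for cytotoxicity, read by sulforhodamine B assay, with a stated time of 48 h; on this read-out higher numbers stand for weaker inhibition and lower numbers for stronger inhibition. Compound 1 `C=CCOc1ccc(Br)cc1C(=O)c1cccnc1` gives 92000 nM, compound 2 `C=CCOc1ccc(C)cc1C(=O)c1cccnc1` gives 84000 nM, and compound 3 `Cc1ccc(O)c(C(=O)c2cccnc2)c1` gives 8040 nM. Compound 1 and compound 2 differ by bromo in place of methyl on an aromatic carbon; the step of a 1.1-fold higher number from compound 2 to compound 1 (0.04 log units; within the scatter) is within the scatter, so these two numbers show no real difference. Compound 3 differs from compound 2 by hydrogen in place of allyl on an oxygen on an aromatic ring, and this step a 10-fold lower number from compound 2 to compound 3 (1.02 log units; beyond the scatter) is large. Compound 4 `O=C(c1cccnc1)c1cc(Br)ccc1O` is still to be measured in this assay. It differs from compound 3 by bromo in place of methyl on an aromatic carbon. This is the same kind of change as that from compound 2 to compound 1, though not the same: in compound 2 the place is para to an allyloxy group, whereas in compound 3 it is para to a hydroxy group. Because the earlier step of a 1.1-fold higher number from compound 2 to compound 1 (0.04 log units; within the scatter) lay within the scatter, a step of similarly small size is expected here. The expected step is a 1.1-fold higher number from compound 3 to compound 4 (0.05 log units; within the scatter). Compound 4 is thus expected to give 9000 nM, somewhere between 4000 nM and 20000 nM.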

Compound 4, half-maximal inhibitory concentration: 53500 nM
Beside the measured number, compound 4's estimate is 5.9-fold (0.77 log units) below it, and the stated range ends below it.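

With a hydroxy group on the ring, bromo in place of methyl gives a 6.7-fold higher number from compound 3 to compound 4 (0.82 log units; beyond the scatter), so in this assay this change does not carry over unchanged from the core with the allyloxy group: the same change on two cores in this assay, a 1.1-fold higher number (0.04 log units; within the scatter) from compound 2 to compound 1 and a 6.7-fold higher number (0.82 log units; beyond the scatter) from compound 3 to compound 4, 6.1-fold (0.78 log units) apart, beyond the scatter of two such steps

The same four compounds can be read the other way, where hydrogen in place of allyl on the oxygen gives a 1.7-fold lower number from compound 1 to compound 4 (0.24 log units; within the scatter), a much smaller step than on the methyl compounds: the same change on two cores in this assay, a 10-fold lower number (1.02 log units; beyond the scatter) from compound 2 to compound 3 and a 1.7-fold lower number (0.24 log units; within the scatter) from compound 1 to compound 4, 6.1-fold (0.78 log units) apart, beyond the scatter of two such steps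

So in these four compounds the effect of each change depends on the other, but the numbers do not show why, and four compounds cannot show whether this holds across the series.

The compounds shown leave open whether another group in the place of methyl or bromo, such as chloro, methoxy or an amine, would follow methyl or bromo on the core of compound 3. They also leave open what a methyl or a longer chain on the oxygen would do in place of allyl.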